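Pyrazine for oxazole on the aryl ring

The source may report more compounds than this note shows. Statements on the series, on what has been measured and on what is new or still open speak of the compounds shown alone.

Compound 1 `c1csc(-c2ccccc2NCC2=NCCN2)c1`: in a functional assay for activation of Alpha-1B adrenergic receptor (Homo sapiens), read by calcium flux (a higher number here means that more compound is needed for the effect, a lower number that less compound is needed), compound 1 gives 5.75 nM.
Compound 2 `c1ccc(-c2cnoc2)c(NCC2=NCCN2)c1`: in this assay compound 2 reaches only the assay limit of < 100000 nM.

Compound 2 thus stands at a limit rather than at a number, with no measurable effect within the tested range. The step that the limit leaves unreadable from compound 1 to compound 2 cannot be sized, as the limit of < 100000 nM in this assay, at which 1 of the 2 values shown sits, shows. Compound 3 `c1ccc(-c2cnccn2)c(NCC2=NCCN2)c1` differs from compound 2 by pyrazin-2-yl in place of 1,2-oxazol-4-yl on an aromatic carbon. Within the data shown here, the single measured step touching this position is a step that the limit leaves unreadable from compound 1 to compound 2; it shows that exchanging the five-membered ring can remove all readable activity, while leaving the size of that loss open. Whether a six-membered ring with two nitrogens behaves more like thiophen-2-yl or more like 1,2-oxazol-4-yl cannot be read from compounds 1 and 2 alone. Compound 3 is nonetheless expected to regain some activity, with the step that the limit leaves unreadable from compound 2 to compound 3 as the estimate, carrying wide uncertainty. The estimate for compound 3 in this assay is 3000 nM, within 100 nM to 60000 nM.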

Compound 3, half-maximal effective concentration: 339 nM
Beside the measured number, compound 3's estimate is 8.8-fold (0.95 log units) above it; the measured number falls inside the stated range.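

Compound 3 shows that this position can carry a six-membered aromatic ring with 2 hetero atoms and keep a readable effect in this assay, which the earlier compounds did not establish, since the only exchange shown there ended at a limit. Pyrazin-2-yl in place of thiophen-2-yl gives a 59-fold higher number from compound 1 to compound 3 (1.77 log units; beyond the scatter), so this is the first exchange at this place whose cost can be sized, and the cost is large, yet activity is not lost altogether. The steps that start or end at compound 2 cannot be read, and the comparison with pyrazin-2-yl stays qualitative, because compound 2 stands at a limit: the limit of < 100000 nM in this assay, at which 1 of the 3 values shown sits.

The compounds shown leave open whether a plain phenyl, a pyridin-2-yl or a furan-2-yl group on this aromatic carbon would stand nearer to compound 1 or to compound 3, and so which feature of thiophen-2-yl goes with the low number of compound 1. They also leave open whether a methyl or an amine on the pyrazin-2-yl ring would move compound 3 in either direction in this assay.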